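Sulfonamide heteroaryl swaps on a diterpenoid lactone series

The compounds below may be only part of what the source reports. "The series", "measured", "known", "first", "only" and "open" are said of these compounds alone.

Measured compounds:
compound 1, `C=C1CC[C@@H]2[C@](C)(COC(C)=O)[C@H](OC(C)=O)CC[C@@]2(C)[C@H]1CC(Nc1ccc(S(=O)(=O)Nc2nccc(C)n2)cc1)C1=CCOC1=O`: 54200 nM
compound 2, `C=C1CC[C@@H]2[C@](C)(COC(C)=O)[C@H](OC(C)=O)CC[C@@]2(C)[C@H]1CC(Nc1ccc(S(=O)(=O)Nc2nccs2)cc1)C1=CCOC1=O`: 59100 nM

Both were read in a functional assay on SF-268 cells (Homo sapiens) for inhibition, read by sulforhodamine B assay, with a stated time of 48 h; on this read-out higher numbers stand for lower toxicity in this test and lower numbers for higher toxicity in this test. Compound 2 gives the highest of the two numbers, yet its nearest neighbour is compound 1, separated only by a 1.1-fold higher number from compound 1 to compound 2 (0.04 log units; within the scatter), a difference inside the scatter. The next compound, compound 3, `C=C1CC[C@@H]2[C@](C)(COC(C)=O)[C@H](OC(C)=O)CC[C@@]2(C)[C@H]1CC(Nc1ccc(S(=O)(=O)Nc2ncccn2)cc1)C1=CCOC1=O`, carries pyrimidin-2-yl in place of 1,3-thiazol-2-yl on a sulfonamide nitrogen. Within the data shown here, the one step that bears on it, the exchange of heteroaryl groups on the same sulfonamide nitrogen from compound 1 to compound 2, stayed within the scatter, so no movement beyond the scatter is expected in this assay, an expected step of a 1.1-fold lower number from compound 2 to compound 3 (0.02 log units; within the scatter). Compound 3 is therefore estimated at 56000 nM, within 28000 nM to 112000 nM.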

Compound 3, concentration lethal to 50% of the cells: 8970 nM
For compound 3 the middle estimate is 6.2-fold (0.80 log units) above the measured one; the whole stated range lies above it.
By their numbers in this assay, from the lowest: compound 3; then compounds 1 and 2 (each within the scatter of the next).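

In this assay the group on the sulfonamide nitrogen does matter: the change to pyrimidin-2-yl from 1,3-thiazol-2-yl gives a 6.6-fold lower number from compound 2 to compound 3 (0.82 log units; beyond the scatter), and hydrogen in place of methyl on an aromatic carbon gives a 6.0-fold lower number from compound 1 to compound 3 (0.78 log units; beyond the scatter). A single methyl therefore separates compound 1 from compound 3, although compound 1 and compound 2 read alike despite carrying different heteroaryl groups. Nothing available explains this shift.

Still open, as far as these compounds go, is whether the lower number needs hydrogen on that aromatic carbon, or whether methoxy or chloro there would keep it. Also open, from the compounds shown here alone, is how a pyridin-2-yl group on the sulfonamide nitrogen would read.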